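A few compounds are considered here, and "the series" means these few. Any claim that something is new, unique, unknown or untested is made for them only; others in the source may bear on it.

Compound 1 `CC(C)[C@H](NC(=O)[C@]1(Cc2ccccc2)CCN1C(=O)OCc1ccccc1)C(N)=O`: in an ADME assay on HELF cells (Homo sapiens) for cytotoxicity, with a stated time of 3 days (on this read-out higher numbers stand for lower toxicity in this test and lower numbers for higher toxicity in this test), compound 1 gives > 100000 nM, a limit of the test and not a number.
Compound 2 `C[C@H](NC(=O)[C@@]1(Cc2ccccc2)CCN1C(=O)OCc1ccccc1)C(=O)NC(C)(C)C`: in this assay compound 2 gives > 100000 nM, again a limit.
Compound 3 `C[C@H](NC(=O)[C@@]1(Cc2ccccc2)CCN1C(=O)OCc1ccccc1)C(=O)N(C)C`: in this assay compound 3 gives > 100000 nM, also a limit.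

Compound 3 therefore stands at the limit of > 100000 nM in this assay, at which 3 of the 3 values shown sit. Among the compounds with values here, the one single-change step, a step that the two limits leave unreadable from compound 2 to compound 3, cannot be read in size, since both ends are limits. Compound 4 `CC(C)[C@H](NC(=O)[C@@]1(Cc2ccccc2)CCN1C(=O)OCc1ccccc1)C(N)=O` is the next compound; it differs from compound 3 by 1-carbamoyl-2-methylpropyl in place of 1-(dimethylcarbamoyl)ethyl on an amide-type nitrogen. Within the data shown here, no measured step bears on this change with a readable size, and compound 1, which carries the entering group, sits at the same limit. The step of a number no higher from compound 3 to compound 4 (the limit leaves the size open) is expected to show nothing beyond the scatter. Compound 4 is estimated at 100000 nM, within 50000 nM to 300000 nM.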

Compound 4, minimum cytotoxic concentration: > 100000 nM
Compound 4 ended at the assay's limit (the forecaster's own chance of this, stated with the estimate: 85%); the middle value lies on the limit itself.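

The steps from compounds 1, 2 and 3 to compound 4 cannot be read in size, as all four values are limits: the limit of > 100000 nM in this assay, at which 4 of the 4 values shown sit. From the compounds shown here alone, how far any change, even of configuration alone, would shift toxicity in this assay stays open, and the closest pair shows this: the fact that compounds 1 and 4 differ only in the configuration as drawn.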